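The compounds below may be only part of what the source reports. "The series", "measured", "known", "first", "only" and "open" are said of these compounds alone.

In a functional assay on A549 cells (Homo sapiens) for antiproliferative activity, read by CCK-8 assay, with a stated time of 48 h (on this read-out higher numbers stand for weaker inhibition and lower numbers for stronger inhibition), compound 1 `COc1ccc(CNC(=O)c2cc(Oc3ccc(/C=C/c4ccccn4)cc3)ccn2)cc1` gives 63600 nM. Compound 2 `O=C(NCc1ccc(F)cc1)c1cc(Oc2ccc(/C=C/c3ccccn3)cc2)ccn1` gives in this assay only a limit of the assay, > 100000 nM. Compound 3 `COc1ccc(CNC(=O)c2cc(Oc3ccc(/C=C/c4ccncc4)cc3)ccn2)cc1` gives 19300 nM in this assay, the lower of the two numbers that are numbers, and shows a 3.3-fold lower number from compound 1 to compound 3 (0.52 log units; beyond the scatter); the cores of compound 1 and compound 3 differ as pyridin-4-yl in place of pyridin-2-yl on a double-bonded chain carbon bound to a double-bonded chain carbon. The change from compound 1 to compound 2 is fluoro in place of methoxy on an aromatic carbon, and it makes an at least 1.5-fold higher number from compound 1 to compound 2 (0.19 log units; that floor lies within the scatter), a step whose size rests on (the limit of > 100000 nM in this assay, at which 1 of the 3 values shown sits). Compound 4 `O=C(NCc1ccc(F)cc1)c1cc(Oc2ccc(/C=C/c3ccncc3)cc2)ccn1` is not yet measured in this assay; it differs from compound 3 by fluoro in place of methoxy on an aromatic carbon, the same change at the same place, made twice in all among these compounds. Because the earlier step is an at least 1.5-fold higher number from compound 1 to compound 2 (0.19 log units; that floor lies within the scatter), the new one is expected to run the same way, toward a higher number, and is estimated as a 2.6-fold higher number from compound 3 to compound 4 (0.41 log units; beyond the scatter). Compound 4 is therefore expected to give about 50000 nM in this assay, most likely between 20000 nM and 150000 nM.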

Compound 4, half-maximal inhibitory concentration: 18200 nM
Beside the measured number, compound 4's estimate is 2.7-fold (0.44 log units) above it; measured number below the stated range.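

Carried onto the pyridin-4-yl compounds, fluoro in place of methoxy gives in this assay a 1.1-fold lower number from compound 3 to compound 4 (0.03 log units; within the scatter), so on this core the swap shows no difference beyond the scatter, and beside the pyridin-2-yl pair the comparison stands thus: the same change on two cores in this assay, an at least 1.5-fold higher number (0.19 log units; that floor lies within the scatter) from compound 1 to compound 2 and a 1.1-fold lower number (0.03 log units; within the scatter) from compound 3 to compound 4; the limit leaves it open whether they differ The other change, pyridin-4-yl in place of pyridin-2-yl, now gives an at least 5.4-fold lower number from compound 2 to compound 4 (0.73 log units; beyond the scatter), so it runs toward a lower number with both methoxy and fluoro in place, and its two readings compare thus: the same change on two cores in this assay, a 3.3-fold lower number (0.52 log units; beyond the scatter) from compound 1 to compound 3 and an at least 5.4-fold lower number (0.73 log units; beyond the scatter) from compound 2 to compound 4; the limit leaves it open whether they differ This shows that the direction of the pyridine change carries over in these two pairs, but it does not show whether the size of either change carries over, since compound 2 stands at a limit of the assay and has no exact number: the limit of > 100000 nM in this assay, at which 1 of the 4 values shown sits.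

The compounds shown leave open how a pyridin-3-yl group would compare with the two pyridine isomers on the same chain. They also leave open whether chloro, or an amine such as dimethylamino, in place of methoxy or fluoro would match these results on either core.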